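The compounds below may be only part of what the source reports. "The series", "measured", "known", "first", "only" and "open" are said of these compounds alone.

Of the compounds shown here, two built on a shared core have been measured so far. Compound 1 `CCOC(=O)c1cnn(-c2nc(-c3ccccc3F)c(C#N)c(=O)n2C)c1N` is one of them, and in a functional assay, with a stated time of 150 min (on this read-out higher numbers stand for weaker inhibition and lower numbers for stronger inhibition), compound 1 gives 87 ug/mL, the higher of the two numbers. Compound 2 `CSc1nc(-c2ccccc2O)c(C#N)c(=O)n1C` gives 58 ug/mL in this assay; the two values lie within the usual scatter of each other and cannot be told apart. Compound 3 `CCOC(=O)c1cnn(-c2nc(-c3cccs3)c(C#N)c(=O)n2C)c1N` differs from compound 1 by thiophen-2-yl in place of 2-fluorophenyl on an aromatic carbon. Among the compounds with values here, no measured pair shows this exchange, so the step from compound 1 to compound 3 is expected to stay within the scatter, in either direction. Compound 3 is therefore estimated at 80 ug/mL, in a range from 35 ug/mL to 200 ug/mL, an expected step of a 1.1-fold lower number from compound 1 to compound 3 (0.04 log units; within the scatter).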

Compound 3, half-maximal inhibitory concentration: 98 ug/mL
For compound 3 the middle estimate is 1.2-fold (0.09 log units) below the measured one; the range from low to high includes it.
By their numbers in this assay, from the lowest: compounds 2, 1 and 3 (each within the scatter of the next).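

Within the data shown here, putting thiophen-2-yl in place of 2-fluorophenyl on this aromatic carbon gives a 1.1-fold higher number from compound 1 to compound 3 (0.05 log units; within the scatter) in this assay and is the only single-place exchange available so far. The two aromatic rings, one five-membered with a sulfur atom and one six-membered with fluorine on it, cannot be told apart at this position. Nothing at hand offers an explanation for this result. Both groups compared are aromatic rings, so the compounds shown leave open how a non-aromatic group here, such as an amine or a longer alkyl chain, would read.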